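A few compounds are considered here, and "the series" means these few. Any claim that something is new, unique, unknown or untested is made for them only; others in the source may bear on it.

Compound 3 `CCCn1c(=O)c2nc(C(C)(O)CC)[nH]c2n(CCC)c1=O` gives the highest number of the three in an assay on cell membranes for binding affinity to adenosine receptor A1 (Cavia porcellus), read by radioligand binding (a higher number here means a weaker inhibitor, a lower number a stronger inhibitor), at 240 nM. Compound 1 `CCCn1c(=O)c2nc([C@@H]3CC4C=CC3C4)[nH]c2n(CCC)c1=O` gives 4.3 nM in this assay and compound 2 `CCCn1c(=O)c2nc([C@H]3CC4C=CC3C4)[nH]c2n(CCC)c1=O` gives 3.4 nM; they differ only in how one stereocentre is drawn, and their step of a 1.3-fold lower number from compound 1 to compound 2 (0.10 log units; within the scatter) sits within the scatter (the fact that one of compounds 1 and 2 is drawn with a defined configuration and the other without, at the place where they differ). Compound 4 `CCCn1c(=O)c2nc(-c3cccn3C)[nH]c2n(CCC)c1=O` carries 1-methyl-1H-pyrrol-2-yl in place of 1-hydroxy-1-methylpropyl on an aromatic carbon. The measured steps that bear on this position are a 56-fold higher number from compound 1 to compound 3 (1.75 log units; beyond the scatter) and a 71-fold higher number from compound 2 to compound 3 (1.85 log units; beyond the scatter), both large, each going from a two-ring carbon group to 1-hydroxy-1-methylpropyl. Putting a ring back at this carbon is therefore expected to bring the number down again in this assay, though perhaps not fully. Compound 4 is estimated at 30 nM, with a range from 5 nM to 150 nM, an expected step of an 8.0-fold lower number from compound 3 to compound 4 (0.90 log units; beyond the scatter).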

Compound 4, inhibition constant: 140 nM
The estimate for compound 4 lay 4.7-fold (0.67 log units) below the measured number; the range from low to high includes it.
By their numbers in this assay, from the lowest: compounds 2 and 1 (each within the scatter of the next); then compounds 4 and 3 (each within the scatter of the next).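

In this assay, a ring at this carbon is not enough in itself: with 1-methyl-1H-pyrrol-2-yl in place of 1-hydroxy-1-methylpropyl, the step is a 1.7-fold lower number from compound 3 to compound 4 (0.23 log units; within the scatter), so the two groups cannot be told apart here. The steps of a 41-fold higher number from compound 2 to compound 4 (1.61 log units; beyond the scatter) and a 33-fold higher number from compound 1 to compound 4 (1.51 log units; beyond the scatter) show that this five-membered aromatic ring does not recover the values of the two-ring carbon group. Nothing given here accounts for this difference.

The compounds shown leave open where a plain cyclopentyl or phenyl group would fall at this carbon. They therefore cannot separate the effect of ring saturation from that of the two-ring framework.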